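Trading trifluoromethyl for cyano on compound 3

A few compounds are considered here, and "the series" means these few. Any claim that something is new, unique, unknown or untested is made for them only; others in the source may bear on it.

In a functional assay on HL-60 cells (Homo sapiens) for cytotoxicity, read by luminescence and CellTiter-Glo, with a stated time of 3 days (a lower number here means a stronger inhibitor, a higher number a weaker inhibitor), compound 3 (`O=C(Nc1ccc(C(F)(F)F)cc1)c1ccc(F)cc1O`) gives 680 nM, the lowest of the three numbers available. Compound 1 (`Cc1ccc(C(=O)Nc2ccc(C#N)cc2)c(O)c1`) gives 2420 nM and compound 2 (`COc1ccc(C(=O)Nc2ccc(C#N)cc2)c(O)c1`) gives 5470 nM. Both carry cyano where compound 3 has trifluoromethyl, but both also differ from it elsewhere. Within the data shown here, compound 4 (`N#Cc1ccc(NC(=O)c2ccc(F)cc2O)cc1`) makes only the single change: cyano in place of trifluoromethyl on an aromatic carbon. Among the measured compounds shown here, the one measured step, a 2.3-fold higher number from compound 1 to compound 2 (0.35 log units; beyond the scatter), is modest and concerns a different change, so no measured step isolates this swap. Because compound 1 with cyano gives 2420 nM the direction expected is upward. A moderate rise is expected, a 2.2-fold higher number from compound 3 to compound 4 (0.34 log units; beyond the scatter). For compound 4 the estimated value is 1500 nM, with a range of 650 nM to 3500 nM.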

Compound 4, half-maximal inhibitory concentration: 1380 nM
Compound 4: the middle estimate sits 1.1-fold (0.04 log units) above what was measured; the range from low to high includes it.
By their numbers in this assay, from the lowest: compound 3; then compounds 4 and 1 (each within the scatter of the next); then compound 2.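

In this assay, the swap on an aromatic carbon para to a large group is now isolated, and cyano in place of trifluoromethyl gives a 2.0-fold higher number from compound 3 to compound 4 (0.31 log units; beyond the scatter) on the shared core. With cyano held fixed, fluoro in place of methoxy gives a 4.0-fold lower number from compound 2 to compound 4 (0.60 log units; beyond the scatter) and so separates those two compounds. Fluoro in place of methyl gives a 1.8-fold lower number from compound 1 to compound 4 (0.24 log units; within the scatter) and so does not separate them.

The compounds shown leave open how an amine or a carboxylic acid at the cyano position would read, and whether the trifluoromethyl step holds with methyl or methoxy on the core. Nothing available accounts for these steps.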